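The compounds below may be only part of what the source reports. "The series", "measured", "known", "first", "only" and "open" are said of these compounds alone.

Of the compounds shown here, three sharing one core have been measured in a functional assay on U-87MG ATCC cells (Homo sapiens) for inhibition; a higher number here means a weaker inhibitor, a lower number a stronger inhibitor. Compound 1 `COc1cc(/C=C/C(=O)c2cccc(NC(=O)c3ccccc3)c2)ccc1O`, which carries a phenyl on a carbonyl carbon, gives 8.82 ug/mL. Compound 2 `COc1cc(/C=C/C(=O)c2cccc(NC(=O)c3cc(Cl)cc(Cl)c3)c2)ccc1O` reaches only the limit of the assay, > 50 ug/mL. Compound 3 `CCOC(=O)C(=O)Nc1cccc(C(=O)/C=C/c2ccc(O)c(OC)c2)c1` likewise reports only a limit, > 50 ug/mL. Thus an at least 5.6-fold higher number from compound 1 to compound 2 (0.75 log units; beyond the scatter) and an at least 5.6-fold higher number from compound 1 to compound 3 (0.75 log units; beyond the scatter), so compound 2 stands at the weak end of what these numbers show. Compound 4 `COc1cc(/C=C/C(=O)c2cccc(NC(C)=O)c2)ccc1O` differs from compound 2 by methyl in place of 3,5-dichlorophenyl on a carbonyl carbon. Within the data shown here, no measured step makes this exact swap, so its size cannot be read directly, but leaving the group that weakened compound 1 points back toward stronger inhibition. Compound 4 is therefore expected to give 20 ug/mL, between 5 ug/mL and 50 ug/mL, which would mean an at least 2.5-fold lower number from compound 2 to compound 4 (0.39 log units; beyond the scatter).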

Compound 4, half-maximal inhibitory concentration: > 50 ug/mL
Compound 4 ended at the assay's limit (the forecaster's own chance of this, stated with the estimate: 35%); middle value at least 2.5-fold (0.39 log units) away from the limit.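

In this assay, swapping phenyl for methyl on this carbonyl carbon also costs inhibition, with an at least 5.6-fold higher number from compound 1 to compound 4 (0.75 log units; beyond the scatter), so a much smaller group than 3,5-dichlorophenyl brings back no readable value. Compound 4 reports only a limit, > 50 ug/mL. The steps among compound 2, compound 3 and compound 4 cannot be read, because these values are not numbers: the limit of > 50 ug/mL in this assay, at which 3 of the 4 values shown sit.

From the compounds shown here alone, what remains open is whether any group other than unsubstituted phenyl can keep inhibition here. A single chlorine on the phenyl, a pyridine ring or a longer chain such as butyl would test this.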